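Dichlorophenyl to dimethoxyphenyl on an aminomethyl side chain

The source may report more compounds than this note shows. Statements on the series, on what has been measured and on what is new or still open speak of the compounds shown alone.

compound 1: `Nc1cc(N)c2nc(-c3ccccc3)c(Oc3ccc(Cl)c(Cl)c3)nc2c1` — < 100000 nM
compound 2: `Nc1cc(N)c2nc(-c3ccccc3)c(NCc3ccc(Cl)c(Cl)c3)nc2c1` — < 100000 nM
compound 3: `Nc1cc(N)c2nc(-c3ccccc3)c(Sc3ccc(Cl)c(Cl)c3)nc2c1` — < 100000 nM

Three measured compounds share one core and differ only in the group attached to it. In a functional assay on MCF7 cells (Homo sapiens) for inhibition, read by sulforhodamine B assay, with a stated time of 48 h (on this read-out higher numbers stand for lower toxicity in this test and lower numbers for higher toxicity in this test), compound 1 gives < 100000 nM, which is a limit of the assay and not a number. Compound 2 gives < 100000 nM, also a limit. Compound 3 gives < 100000 nM, again a limit. For the measured compounds named here, the one step between compounds that differ in a single place, a step that the two limits leave unreadable from compound 1 to compound 3, cannot be read because the limit of < 100000 nM in this assay, at which 3 of the 3 values shown sit, holds both of its ends. Compound 2 therefore stands only at that limit, and the two other values shown beside it are limits as well.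

Compound 4, `COc1ccc(CNc2nc3cc(N)cc(N)c3nc2-c2ccccc2)cc1OC`, arises from compound 2 by 3,4-dimethoxyphenyl in place of 3,4-dichlorophenyl on a saturated chain carbon bound to a nitrogen on an aromatic ring. Going by the values given here, no measured step touches this change, since the only step available is unreadable and every value sits at the same limit. No direction and no size beyond the scatter can be drawn from the data for this assay. Compound 4 is expected to give 30000 nM, within 5000 nM to 100000 nM, and it is likely that only a limit is reported. The step this estimate means is a step that the limit leaves unreadable from compound 2 to compound 4, expected rather than measured.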

Compound 4, concentration lethal to 50% of the cells: < 100000 nM
Compound 4 gave a limit, no number (the forecaster's own chance of this, stated with the estimate: 60%); the middle value lies beyond the limit too.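

No step can be read from compound 2 to compound 4, nor any other new step, because the values give no number to compare: the limit of < 100000 nM in this assay, at which 4 of the 4 values shown sit. The compounds shown leave open how large the true values are and whether 3,4-dimethoxyphenyl and 3,4-dichlorophenyl differ at all in this test.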